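Triazole sulfonamide series: aryl substituent and cytotoxicity

The source may report more compounds than this note shows. Statements on the series, on what has been measured and on what is new or still open speak of the compounds shown alone.

Measured so far:
- compound 1, `Cc1cccc(-n2cc(-c3ccccc3NS(=O)(=O)c3c[nH]c(=O)[nH]c3=O)nn2)c1`: 21900 nM
- compound 2, `Cc1ccc(-n2cc(-c3ccccc3NS(=O)(=O)c3c[nH]c(=O)[nH]c3=O)nn2)cc1`: > 100000 nM

Compound 1 carries a 3-methylphenyl on the triazole nitrogen and in an ADME assay on L02 cells (Homo sapiens) for cytotoxicity, read by MTT assay, with a stated time of 24 h (a higher number here means that more compound is tolerated, a lower number that less compound is tolerated), compound 1 gives 21900 nM. For compound 2, with a 4-methylphenyl in the same place, this assay returns only a limit, > 100000 nM, because the value sits at the limit of > 100000 nM in this assay, at which 1 of the 2 values shown sits. Among the compounds with values here, the one measured step, an at least 4.5-fold higher number from compound 1 to compound 2 (0.65 log units; beyond the scatter), therefore has a known lower bound only, and compound 2 stands at the tolerated end of the pair without a fixed number.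

Compound 3, `O=c1[nH]cc(S(=O)(=O)Nc2ccccc2-c2cn(-c3cccc(F)c3)nn2)c(=O)[nH]1`, is not yet measured. It differs from compound 2 by 3-fluorophenyl in place of 4-methylphenyl on an aromatic nitrogen. In name the 3-fluorophenyl of compound 3 is closer to the 3-methylphenyl of compound 1 than to the 4-methylphenyl of compound 2. Within the data shown here, the only step that bears on this change is the one from compound 1 to compound 2, which moved the number up by at least a modest amount; a return toward a ring substituted as in compound 1 makes a move back down, in this assay, the more likely outcome, though fluorine is not methyl and nothing measured fixes its size.

Compound 3 is expected to give 40000 nM, with a range of 15000 nM to 100000 nM. This estimate corresponds to an expected step of an at least 2.5-fold lower number from compound 2 to compound 3 (0.39 log units; beyond the scatter), a decrease relative to compound 2, with a real chance that only a limit is again reported.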

Compound 3, half-maximal cytotoxic concentration: "not toxic" (no number reported)
For compound 3 the study gives words and no number; no gap can be computed for the estimate.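

In this assay, within the data shown here, compound 3 is reported only in words, as "not toxic", with no number, so no step linking it to compound 1 or compound 2 can be read. The compounds shown leave open how the tolerated concentration of compound 3, with its 3-fluorophenyl, compares numerically with that of either methylphenyl compound.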